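Tolerated concentration across the series: the step to compound 4

The compounds below may be only part of what the source reports. "The series", "measured", "known", "first", "only" and "open" are said of these compounds alone.

Three substituents on the ring amide nitrogen of the shared core have been tested so far. Compound 1 `COc1ccc([C@H]2CC(=O)N(Cc3cccc(N)c3)C2)cc1OC1CCCC1` bears a 3-aminobenzyl group there, compound 2 `COc1ccc([C@H]2CC(=O)N(Cc3cccc([N+](=O)[O-])c3)C2)cc1OC1CCCC1` a 3-nitrobenzyl group, and compound 3 `COc1ccc([C@H]2CC(=O)N(C(C)=O)C2)cc1OC1CCCC1` an acetyl group. In a functional assay on HEK293 cells (Homo sapiens) for cytotoxicity (a higher number here means that more compound is tolerated, a lower number that less compound is tolerated), compound 1 gives > 10000 nM, which is a limit of the assay and not a number. Compound 2 likewise gives only a limit, > 10000 nM. Compound 3 also sits at a limit, > 10000 nM. The three steps between them, a step that the two limits leave unreadable from compound 1 to compound 2, a step that the two limits leave unreadable from compound 1 to compound 3 and a step that the two limits leave unreadable from compound 2 to compound 3, cannot be read in size because all values share one limit (the limit of > 10000 nM in this assay, at which 3 of the 3 values shown sit).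

Compound 4 `COc1ccc([C@H]2CC(=O)N(c3cccc(O)c3)C2)cc1OC1CCCC1` differs from compound 3 in one place: 3-hydroxyphenyl in place of acetyl on an amide-type nitrogen in a ring. Among the compounds with values here, no measured step bears directly on this change; the series shows only that neither the exchange of amino for nitro nor the exchange of a benzyl group for acetyl brought any compound below the limit. Compound 4 is therefore expected to remain at the limit too, with an expected step that the limit leaves unreadable from compound 3 to compound 4 that is not beyond the scatter. The estimate for compound 4 is 15000 nM, with a range from 7000 nM to 40000 nM.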

Compound 4, half-maximal cytotoxic concentration: > 10000 nM
Compound 4 ended at the assay's limit (the forecaster's own chance of this, stated with the estimate: 85%); the middle value lies beyond the limit too.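

No step between compound 4 and compound 1, compound 2 or compound 3 can be read in size, because all four values are a limit and not a number: the limit of > 10000 nM in this assay, at which 4 of the 4 values shown sit.

The compounds shown leave open how far apart these four lie in tolerated concentration, and whether any substituent on the ring amide nitrogen brings a value inside the limit.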